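From Bromo to Fluoro on the Aromatic Ring

This account rests on a few compounds, and the source may have more. Where it says the series, first, only, none or still open, it means among the compounds named here.

In a functional assay on K562/A02 cells (Homo sapiens) for antiproliferative activity, read by MTT assay (a lower number here means a stronger inhibitor, a higher number a weaker inhibitor), compound 1 `O=C(CCCCCNC(=S)NN=C(c1ccccc1)c1ccccc1)NO` gives 3640 nM, while compound 2 `C/C(=N\NC(=S)NCCCCCC(=O)NO)c1ccc(Br)cc1` gives 440 nM, the lower of the two numbers and a gap beyond the usual scatter. Compound 3 `C/C(=N\NC(=S)NCCCCCC(=O)NO)c1ccc(F)cc1` differs from compound 2 in one place: fluoro in place of bromo on an aromatic carbon. Within the data shown here, no measured pair shows the effect of this change, so only a small move toward a higher number, probably within the scatter, is expected. The expected change is a 1.6-fold higher number from compound 2 to compound 3 (0.20 log units; within the scatter). For compound 3 the estimated value is 700 nM, with an expected range from 250 nM to 2000 nM.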

Compound 3, half-maximal inhibitory concentration: 1020 nM
Compound 3: the middle estimate sits 1.5-fold (0.16 log units) below what was measured; the measured number falls inside the stated range.
By their numbers in this assay, from the lowest: compound 2; then compound 3; then compound 1.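

In this assay, among these compounds, this is the first direct reading of a single change on the shared core: going from 4-bromophenyl to 4-fluorophenyl gives a 2.3-fold higher number from compound 2 to compound 3 (0.37 log units; beyond the scatter) and so moves the number beyond the usual scatter. The position therefore responds to which halogen it carries, although the step is modest and rests on one pair. Nothing available explains why the number moves.

Going by these compounds, how chloro, an amine or a carboxylic acid at this place would compare with bromo remains open. So does whether the same exchange gives a similar step on another core.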